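Hydroxy to ethyl on the side chain, two cores

The compounds below may be only part of what the source reports. "The series", "measured", "known", "first", "only" and "open" are said of these compounds alone.

Compound 1 `CN(CCO)/N=N/c1[nH]cnc1C(N)=O` and compound 3 `CN(CCO)/N=N/c1n[nH]cc1C(N)=O` are built from the same atoms joined differently; the difference between the two cores is not broken down here. In a functional assay on L1210 cells (Mus musculus) for antiproliferative activity (a lower number here means a less potent compound, a higher number a more potent compound, by a factor of ten per unit of this negative logarithm), compound 1 gives 3.12, and in this assay compound 3 gives 3.1, so the two stand within the scatter of each other. Compound 2 `CCCCN(C)/N=N/c1[nH]cnc1C(N)=O` carries ethyl in place of hydroxy on a saturated chain carbon, two bonds along the chain from an amine nitrogen relative to compound 1, and in this assay compound 2 gives 3.54, which makes a number 0.42 log units higher from compound 1 to compound 2 (beyond the scatter).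

Compound 4 `CCCCN(C)/N=N/c1n[nH]cc1C(N)=O` is not yet measured. Relative to compound 3 it carries ethyl in place of hydroxy on a saturated chain carbon, two bonds along the chain from an amine nitrogen; the place is described in the same words as for the change from compound 1 to compound 2, so this is the same change, occurring twice among the compounds shown. For the measured compounds named here, for compound 4 a step of a number 0.40 log units higher from compound 3 to compound 4 (beyond the scatter) in this assay is expected, set beside the measured one, because a number 0.42 log units higher from compound 1 to compound 2 (beyond the scatter) is the single reading of this change and compound 3 starts from a value within the scatter of compound 1. Compound 4 is therefore estimated at 3.5, between 3.2 and 3.8.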

Compound 4, logarithm of the reciprocal of the active concentration, log(1/C): 3.81
Beside the measured number, compound 4's estimate is 0.31 log units below it, outside the stated range (above it).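

In this assay, ethyl in place of hydroxy on a saturated chain carbon, two bonds along the chain from an amine nitrogen, gives a number 0.71 log units higher from compound 3 to compound 4 (beyond the scatter) on the second core. For the compounds shown here, this is only two pairs and one change, so it shows that the step carries between these two cores in direction and in size, but not that it would carry to any other core, nor why the number rises. The two readings cannot be told apart, so the larger figure on the second core is no evidence that this core responds more strongly: the same change on two cores in this assay, a number 0.42 log units higher (beyond the scatter) from compound 1 to compound 2 and a number 0.71 log units higher (beyond the scatter) from compound 3 to compound 4, 0.29 log units apart, within the scatter of two such steps

The compounds shown leave open whether the rise follows from losing the hydroxy or from the longer chain, since 2-hydroxyethyl to butyl changes both at once. Also open, on these data alone, is how the two cores would behave with a side chain ending in an amine or a carboxylic acid, or with a chain longer than butyl.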